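Removing one methyl from a compound at the assay limit

This account rests on a few compounds, and the source may have more. Where it says the series, first, only, none or still open, it means among the compounds named here.

Compound 1 `C/C(=C\CC/C(C)=C/CC[C@@H]1[C@@]2(C)CCC(=O)C(C)(C)[C@H]2CC[C@@]1(C)O)CC/C=C(\C)C(=O)OCc1cn(-c2ccc(F)cc2)nn1` gives > 150000 nM as a limit
Compound 2 `C/C(=C\CC/C(C)=C/CC[C@@H]1[C@@]2(C)CCC(=O)C(C)(C)[C@H]2CC[C@@]1(C)O)CC/C=C(\C)C(=O)OCc1cn(-c2ccc([N+](=O)[O-])cc2)nn1` gives > 150000 nM as a limit
Compound 3 `C/C(=C\CC/C(C)=C/CC[C@@H]1[C@@]2(C)CCC(=O)C(C)(C)[C@H]2CC[C@@]1(C)O)CC/C=C(\C)C(=O)OCc1cn(-c2cccc(C)c2)nn1` gives > 150000 nM as a limit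

In an ADME assay on L132 cells (Homo sapiens) for cytotoxicity, read by MTT assay, with a stated time of 48 h (on this read-out lower numbers stand for stronger inhibition and higher numbers for weaker inhibition), compound 3 gives > 150000 nM as a limit and not as a number. The whole set rests on the limit of > 150000 nM in this assay, at which 3 of the 3 values shown sit, and offers nothing finer to compare.

Compound 4 `C/C(=C\CC/C(C)=C/CC[C@@H]1[C@@]2(C)CCC(=O)C(C)(C)[C@H]2CC[C@@]1(C)O)CC/C=C(\C)C(=O)OCc1cn(-c2ccccc2)nn1` differs from compound 3 by hydrogen in place of methyl on an aromatic carbon and the change is hydrogen in place of methyl on an aromatic carbon, turning 3-methylphenyl into phenyl.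

The closest measured changes also alter this aromatic group: a step that the two limits leave unreadable from compound 1 to compound 3 and a step that the two limits leave unreadable from compound 2 to compound 3 have no readable size, and neither has a step that the two limits leave unreadable from compound 1 to compound 2 in the same group. None of them points in a direction, so no step beyond the scatter is expected in this assay for this small change. The expected step is a step that the limit leaves unreadable from compound 3 to compound 4 as an estimate only.

For compound 4 the expected value is 200000 nM with an estimated range from 100000 nM to 400000 nM and another limit is the likeliest report.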

Compound 4, half-maximal inhibitory concentration: > 150000 nM
Compound 4 was reported as a limit (the forecaster's own chance of this, stated with the estimate: 85%); the middle value does not contradict the limit.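

Compound 4 also gives > 150000 nM, a limit and not a number, so no step among compound 1, compound 2, compound 3 and compound 4 can be read: the limit of > 150000 nM in this assay, at which 4 of the 4 values shown sit.

These compounds leave open whether changing the group on the phenyl ring alters cytotoxicity at all, and at what concentration any of them would reach half-maximal inhibition.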